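The source may hold more compounds than are shown below. What is called first, only, known or untested is meant among the compounds shown, and "the series" means these compounds.

Compound 1 `O=C(NCCO)c1cccc(-c2cccc3cc(Cc4cccc(C(F)(F)F)c4)sc23)c1` is the starting point of this account. In a functional assay on CHO cells for agonist activity at G-protein coupled receptor 52 (Homo sapiens), read by AlphaScreen and cAMP accumulation, with a stated time of 30 min (on this read-out lower numbers stand for smaller maximal responses and higher numbers for larger maximal responses), compound 1 gives 79.6%, the highest of the three numbers measured, though its nearest neighbour lies within the usual scatter. Compound 3 `Cc1c(Cc2cccc(C(F)(F)F)c2)oc2c(-c3cccc(C(=O)NCCO)c3)cccc12` gives 71.5% in this assay, a number that cannot be told apart from that of compound 1 with any confidence. Compound 2 `O=C(NCCO)c1cccc(-c2cccc3c2CC(Cc2cccc(C(F)(F)F)c2)O3)c1` gives 45.9% in this assay, and this gap to compound 1 does lie beyond the scatter. Within the data shown here, none of the three measured compounds differs from another in a single place, so no measured step is available to guide the next move.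

Compound 4 `NC(=O)CNC(=O)c1cccc(-c2cccc3cc(Cc4cccc(C(F)(F)F)c4)sc23)c1` is the compound not yet measured. It differs from compound 1 in one place, with the difference counted as carbamoyl in place of hydroxymethyl on a saturated chain carbon bound to an amide-type nitrogen. Among the measured compounds shown here, since no measured pair shows the same change, the expectation rests on compound 1 alone, taken as the anchor. A modest downward move is expected, of a size that may not exceed the scatter, so that compound 4 is estimated to stay in the same region as compound 1. The step from compound 1 to compound 4 in this assay is expected to be a number 9.6 percentage points lower from compound 1 to compound 4 (within the scatter). Compound 4 is therefore estimated at 70%, with a range from 50% to 90%.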

Compound 4, largest response reached (Emax), in percent of the reference or control that the assay uses: 102%
Compound 4: the middle estimate sits 32 percentage points below what was measured; the measured number lies above the stated range.
By their numbers in this assay, from the lowest: compound 2; then compounds 3 and 1 (each within the scatter of the next); then compound 4.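

Among these compounds, the swap of hydroxymethyl for carbamoyl on a saturated chain carbon bound to an amide-type nitrogen gives the first single-place step in this assay, and it is a number 22.4 percentage points higher from compound 1 to compound 4 (beyond the scatter). Among the compounds shown here, it shows that, with the core of compound 1 unchanged, the largest response depends on the end of this side chain, something the earlier compounds could not show because none of them differed from another in one place only. The group that leaves and the group that enters each count one hydrogen-bond donor and one hydrogen-bond acceptor, so those counts do not separate them, and nothing available here gives a reason for the step.

The compounds shown leave open whether carbamoyl in place of hydroxymethyl would give a step of similar size on the cores of compound 2 and compound 3, since this single pair shares the core of compound 1. They also leave open what a carboxylic acid, an amine or a longer chain ending in carbamoyl would do at this place on the chain.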